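Octadecyl amide of compound 2: expected cytotoxicity in A-431 cells

The compounds below may be only part of what the source reports. "The series", "measured", "known", "first", "only" and "open" are said of these compounds alone.

Compound 2 `CCCCCCCCNC(=O)[C@@H](NC(=O)/C=C/c1ccccc1)[C@@H](C)O` gives 36000 nM in a functional assay on A-431 cells (Homo sapiens) for cytotoxicity, read by MTT assay, with a stated time of 48 h; on this read-out higher numbers stand for weaker inhibition and lower numbers for stronger inhibition. It stands second highest of the three numbers measured: compound 1 `CCCCCCCCNC(=O)[C@@H](NC(=O)c1cccs1)[C@@H](C)O` gives 32200 nM and compound 3 `C/C=C/C=C/C(=O)N[C@H](C(=O)NCCCCCCCC)[C@@H](C)O` gives 58200 nM, with steps a 1.1-fold higher number from compound 1 to compound 2 (0.05 log units; within the scatter), a 1.6-fold higher number from compound 2 to compound 3 (0.21 log units; within the scatter) and a 1.8-fold higher number from compound 1 to compound 3 (0.26 log units; within the scatter), all within the scatter. Compound 4 `CCCCCCCCCCCCCCCCCCNC(=O)[C@@H](NC(=O)/C=C/c1ccccc1)[C@@H](C)O` differs from compound 2 by decyl in place of hydrogen on a saturated chain carbon, eight bonds along the chain from an amide-type nitrogen. Among the compounds with values here, none of the measured steps touches this part of the series; each of them changes the acyl group on the other side of the shared core, and each stays within the scatter. Within the data shown here, no measured step therefore bears on the change, and the expectation for compound 4 is a number near that of compound 2 with wide uncertainty, no change at the digits printed from compound 2 to compound 4 (within the scatter). Compound 4 is estimated at 36000 nM, within 9000 nM to 150000 nM.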

Compound 4, half-maximal inhibitory concentration: 177000 nM
Compound 4: middle estimate off by 4.9-fold (0.69 log units), on the low side; the measured number lies above the stated range.
By their numbers in this assay, from the lowest: compounds 1, 2 and 3 (each within the scatter of the next); then compound 4.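

In this assay, within the data shown here, this position gives the first step beyond the scatter: decyl in place of hydrogen on a saturated chain carbon yields a 4.9-fold higher number from compound 2 to compound 4 (0.69 log units; beyond the scatter), a modest loss of inhibition. The acyl changes among compounds 1, 2 and 3 all stayed within the scatter, so the chain is the only place shown where the number moves. Nothing shown accounts for this step.

Going by these compounds, whether decyl acts alike with the acyl groups of compound 1 and compound 3 remains open. Also open, on these data alone, is how the number behaves with a shorter added chain, such as hexyl, or with an amine on the chain.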